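Compound 4 against compound 1: expected effect of ring-amine acylation

The source may report more compounds than this note shows. Statements on the series, on what has been measured and on what is new or still open speak of the compounds shown alone.

The shared core is that of compound 1 `CCCCNc1nc(N)nc2c1CNCC2`. Going by the values given here, in an assay on HEK293 cells for agonist activity at Toll-like receptor 8 (Homo sapiens), read by a luciferase reporter, with a stated time of 6 h (a higher number here means that more compound is needed for the effect, a lower number that less compound is needed), compound 1 gives 7.2 uM, the highest of the three numbers measured so far. Compound 2 `CCCCNc1nc(N)nc2c1CCN(C(C)=O)C2` gives 0.4 uM in this assay, a number below that of compound 1 by a margin beyond the usual scatter. Compound 3 `CCCCNc1nc(N)nc2c1CN(Cc1ccc(OC(F)(F)F)cc1)CC2` gives 0.24 uM in this assay, likewise well below compound 1 and beyond the scatter; compound 2 and compound 3 sit within the scatter of each other, so no order between them is claimed.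

Compound 4 `CCCCNc1nc(N)nc2c1CN(C(=O)c1csc(N)n1)CC2` has not yet been measured in this assay. It differs from compound 1 in one place: (2-amino-1,3-thiazol-4-yl)carbonyl in place of hydrogen on an amine nitrogen in a ring. Among the compounds with values here, no step between measured compounds carries exactly this change, so the expectation rests on compound 2 and compound 3, both of which give numbers far below compound 1 in this assay. Compound 4 is expected to fall in the same region, with a step of a 21-fold lower number from compound 1 to compound 4 (1.31 log units; beyond the scatter) expected to run downward and beyond the scatter. The estimate for compound 4 in this assay is 0.35 uM, with a range from 0.1 uM to 1.2 uM.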

Compound 4, minimum effective concentration: 6.9 uM
For compound 4 the middle estimate is 20-fold (1.29 log units) below the measured one, outside the stated range (above it).
By their numbers in this assay, from the lowest: compounds 3 and 2 (each within the scatter of the next); then compounds 4 and 1 (each within the scatter of the next).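

In this assay, the step on putting (2-amino-1,3-thiazol-4-yl)carbonyl in place of hydrogen on the amine nitrogen in the ring is a 1.0-fold lower number from compound 1 to compound 4 (0.02 log units; within the scatter), so this group, with its 8 heavy atoms, leaves the number where it stood without the substituent. A low number is therefore not a general outcome of substituting this nitrogen: compound 3, with a different group at the same place, gives 0.24 uM, while compound 4 gives 6.9 uM, so the identity of the entering group matters here, not just the presence of one. No measurement at hand bears on why this group leaves the number unchanged.

Open, on these data alone, is whether a benzoyl group, or a thiazolylcarbonyl group lacking the amino group, on this same nitrogen would give a number near that of compound 4 or near that of compound 3. Also open is whether the carbonyl link or the aminothiazole ring sets the result for compound 4, since the compounds shown do not vary these two parts separately at this position.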